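A few compounds are considered here, and "the series" means these few. Any claim that something is new, unique, unknown or untested is made for them only; others in the source may bear on it.

In a functional assay on HeLa cells (Homo sapiens) for antiproliferative activity, read by MTT assay, with a stated time of 72 h (a lower number here means a stronger inhibitor, a higher number a weaker inhibitor), compound 1 (`O=C1COc2ccc(-c3cccc(NS(=O)(=O)c4ccc(F)cc4)c3)cc2N1`) gives > 40000 nM and this is a limit of the assay, not a number. Compound 2 (`COc1cccc(N2C(=O)COc3ccc(-c4cnc(OC)c(NS(=O)(=O)c5ccc(F)cc5)c4)cc32)c1`), which carries a methoxy-bearing phenyl on the amide-type nitrogen in a ring and differs elsewhere too, gives > 40000 nM and this is also a limit. Within the data shown here, no measured step therefore exists to scale from. Compound 3 (`COc1ccc(N2C(=O)COc3ccc(-c4cccc(NS(=O)(=O)c5ccc(F)cc5)c4)cc32)cc1`) keeps the core of compound 1 and changes one place: 4-methoxyphenyl in place of hydrogen on an amide-type nitrogen in a ring with 4-methoxyphenyl in place of hydrogen on an amide-type nitrogen in a ring. With compound 2 showing no number (the limit of > 40000 nM in this assay, at which 2 of the 2 values shown sit), only a small step is expected in this assay and, if one appears at all, towards stronger inhibition. The expected outcome is an at least 1.3-fold lower number from compound 1 to compound 3 (0.12 log units; that floor lies within the scatter) as an estimate. For compound 3 the estimated half-maximal inhibitory concentration is 30000 nM with an expected range from 8000 nM to 40000 nM in this estimate.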

Compound 3, half-maximal inhibitory concentration: 13200 nM
Compound 3: middle estimate off by 2.3-fold (0.36 log units), on the high side; measured number inside the range.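

In this assay, the position on the amide-type nitrogen in a ring proves responsive: 4-methoxyphenyl in place of hydrogen there gives an at least 3.0-fold lower number from compound 1 to compound 3 (0.48 log units; beyond the scatter), and this single change yields the first measured number among the compounds shown. Compound 1 gives > 40000 nM, which is a limit of the assay and not a number. The true size of the step therefore remains unknown, and the printed figure is only its floor: the limit of > 40000 nM in this assay, at which 2 of the 3 values shown sit.

The compounds shown leave open whether the gain requires the methoxy group or whether a plain phenyl, a benzyl or a short alkyl chain on the same nitrogen would do as much. They also leave open how a group carrying an amine or a carboxylic acid would fare at this position.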